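Compound 1 and the amide change to compound 3

A few compounds are considered here, and "the series" means these few. Any claim that something is new, unique, unknown or untested is made for them only; others in the source may bear on it.

Compound 1 `COc1ccc(NC(=O)[C@@H]2CC=C(CCC=C(C)C)C[C@H]2c2ccccc2)cc1` carries an amide on its shared core. In an assay on isolated protein for inhibition of Apoptosis regulator Bcl-2 (Homo sapiens), read by fluorescence polarization, with stated times of 5 min and 10 min (a lower number here means a stronger inhibitor, a higher number a weaker inhibitor), compound 1 gives only a limit, > 23000 nM. Compound 2 `COC(=O)c1ccc(NC(=O)[C@@H]2CC=C(CCC=C(C)C)C[C@H]2c2ccccc2)cc1` differs from it in one place, methoxycarbonyl in place of methoxy on an aromatic carbon. In this assay compound 2 likewise returns a limit, > 23000 nM. The step that the two limits leave unreadable from compound 1 to compound 2 cannot be read because of the limit of > 23000 nM in this assay, at which 2 of the 2 values shown sit. Compound 3 `CON(C)C(=O)[C@@H]1CC=C(CCC=C(C)C)C[C@H]1c1ccccc1` is the one not yet measured; it differs from compound 1 as follows: methoxy(methyl)amino in place of (4-methoxyphenyl)amino on a carbonyl carbon. Within the data shown here, no measured step bears on this change, and compound 1 itself offers no number to start from, only its limit. The size of the step that the limit leaves unreadable from compound 1 to compound 3 is therefore an expectation resting on nothing firmer than the two limits shown. For compound 3 the estimate in this assay is 30000 nM, within 8000 nM to 100000 nM, with a limit again the most probable outcome.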

Compound 3, inhibition constant: > 23000 nM
Compound 3 ended at the assay's limit; the forecaster's own chance of this, stated with the estimate: 85%; the middle value does not contradict the limit.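

The step from compound 1 to compound 3 cannot be read, because compound 3, like compound 1, gives only a limit: the limit of > 23000 nM in this assay, at which 3 of the 3 values shown sit.

The compounds shown leave open how the groups on the carbonyl carbon or the aromatic carbon rank against one another in this assay.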